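The source may report more compounds than this note shows. Statements on the series, on what has been measured and on what is new or still open speak of the compounds shown alone.

In an ADME assay on Vero cells (Chlorocebus sabaeus) for cytotoxicity, with a stated time of 7 days (a lower number here means that less compound is tolerated, a higher number that more compound is tolerated), compound 1 `COc1ccc2[nH]c(C(=O)N3CC(=O)N(Cc4ccccc4)[C@@H](COCc4ccccc4)C3)cc2c1` gives > 30000 nM, which is a limit and not a number. Compound 2 `COc1ccc2[nH]c(C(=O)N3CC(=O)N(Cc4ccccc4)[C@@H](COC(C)(C)C)C3)cc2c1` gives 78200 nM and compound 3 `COc1ccc2[nH]c(C(=O)N3CC(=O)N(Cc4ccccc4)[C@@H](CN4C(=O)c5ccccc5C4=O)C3)cc2c1` gives 41000 nM, and these two values agree within the usual scatter. Compound 4 `COc1ccc2[nH]c(C(=O)N3CC(=O)N(Cc4ccccc4)[C@@H](CN4CCC(C(C)C)CC4)C3)cc2c1` differs from compound 3 in one place: a group of 9 heavy atoms (8 carbon, 1 nitrogen; one six-membered non-aromatic ring with 1 hetero atom) in place of a group of 11 heavy atoms (8 carbon, 1 nitrogen, 2 oxygen; one five-membered non-aromatic ring with 1 hetero atom, one six-membered aromatic ring of carbon only), on a saturated chain carbon bound to a saturated ring carbon. The steps that start at compound 1 have no readable size because of the limit of > 30000 nM in this assay, at which 1 of the 3 values shown sits. Going by the values given here, the one readable change at this place is a 1.9-fold lower number from compound 2 to compound 3 (0.28 log units; within the scatter), so a swap of groups here has so far moved the number only within the scatter. On that single step, the expected change is small, a 1.6-fold lower number from compound 3 to compound 4 (0.21 log units; within the scatter), and not beyond the scatter. For compound 4 the estimated value is 25000 nM, with an expected range from 8000 nM to 70000 nM.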

Compound 4, half-maximal cytotoxic concentration: 3800 nM
Estimate against measurement, compound 4: 6.6-fold (0.82 log units) above; the measured number lies below the stated range.
By their numbers in this assay, from the lowest: compound 4; then compounds 3 and 2 (each within the scatter of the next).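

In this assay, going by these compounds alone, the group on this saturated chain carbon bound to a saturated ring carbon can move the number well beyond the scatter: with 4-isopropylpiperidin-1-yl there is an 11-fold lower number from compound 3 to compound 4 (1.03 log units; beyond the scatter) and a 21-fold lower number from compound 2 to compound 4 (1.31 log units; beyond the scatter), whereas the one earlier readable swap stayed within the scatter. The further step, an at least 7.8-fold lower number from compound 1 to compound 4 (0.89 log units; beyond the scatter), gives only a minimum size because compound 1 carries a limit and not a number: the limit of > 30000 nM in this assay, at which 1 of the 4 values shown sits.

The compounds shown do not separate the contribution of the piperidine ring from that of its isopropyl group. A plain piperidin-1-yl, or a 4-isopropylcyclohexyl group with carbon in place of the ring nitrogen, would help tell them apart.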